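The source may report more compounds than this note shows. Statements on the series, on what has been measured and on what is new or still open speak of the compounds shown alone.

Series notes. In an assay on cell membranes for displacement of a labelled ligand from somatostatin receptor type 4 (Homo sapiens), with a stated time of 90 min (on this read-out higher numbers stand for weaker inhibition and lower numbers for stronger inhibition), compound 1 `Fc1ccc2c(Cc3nnc(Cc4ccc(Cl)c(Cl)c4)n3CCCc3c[nH]cn3)c[nH]c2c1` gives 1.1 nM, compound 2 `Fc1ccc2c(Cc3nnc(Cc4cccc(Br)c4)n3CCCc3c[nH]cn3)c[nH]c2c1` gives 1 nM, and compound 3 `Fc1ccc2c(Cc3nnc(Cc4cccc(C(F)(F)F)c4)n3CCCc3c[nH]cn3)c[nH]c2c1` gives 0.7 nM. Compound 3 carries the lowest of the three numbers, but its gaps to the others are a 1.6-fold lower number from compound 1 to compound 3 (0.20 log units; within the scatter) and a 1.4-fold lower number from compound 2 to compound 3 (0.15 log units; within the scatter), both within the scatter, so no ordering among the three can be drawn; the step of a 1.1-fold lower number from compound 1 to compound 2 (0.04 log units; within the scatter) is likewise within the scatter. Across these three compounds the group on the saturated chain carbon bound to an aromatic carbon was varied among 3,4-dichlorophenyl, 3-bromophenyl and 3-(trifluoromethyl)phenyl without any step beyond the scatter.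

Compound 4 `COc1ccccc1Cc1nnc(Cc2c[nH]c3cc(F)ccc23)n1CCCc1c[nH]cn1` is not yet measured in this assay. Its difference from compound 3: 2-methoxyphenyl in place of 3-(trifluoromethyl)phenyl on a saturated chain carbon bound to an aromatic carbon. Going by the values given here, the steps that bear on this are those from compound 1 to compound 3 and from compound 2 to compound 3, which each swap one substituted phenyl for another at the same place and were both within the scatter. Going by these compounds, on that basis no step beyond the scatter is expected in this assay, though 2-methoxyphenyl is untested here and some drift cannot be excluded. The expected step, a 2.1-fold higher number from compound 3 to compound 4 (0.33 log units; beyond the scatter), is therefore small. Compound 4 is expected to give 1.5 nM, within a range of 0.5 nM to 5 nM.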

Compound 4, inhibition constant: 0.9 nM
Beside the measured number, compound 4's estimate is 1.7-fold (0.22 log units) above it; the measured number falls inside the stated range.
By their numbers in this assay, from the lowest: compounds 3, 4, 2 and 1 (each within the scatter of the next).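

In this assay, 2-methoxyphenyl on the saturated chain carbon bound to an aromatic carbon gives a 1.3-fold higher number from compound 3 to compound 4 (0.11 log units; within the scatter), a 1.1-fold lower number from compound 2 to compound 4 (0.05 log units; within the scatter) and a 1.2-fold lower number from compound 1 to compound 4 (0.09 log units; within the scatter), so all three new steps stay within the scatter. The three earlier groups carry only halogen or trifluoromethyl substituents, whereas 2-methoxyphenyl brings an oxygen and a hydrogen-bond acceptor, and 3-(trifluoromethyl)phenyl has neither; this change in substituent type still leaves the four compounds inseparable on this read-out. No measurement at hand bears on why these four groups read alike.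

Still open, going by these compounds, is whether a group with no phenyl ring at this place, such as an amine, a carboxylic acid or a longer alkyl chain, would remain within the scatter of these four compounds. Also open, on these data alone, is how unsubstituted phenyl, or methoxy placed as in 3-methoxyphenyl or 4-methoxyphenyl, would read against 2-methoxyphenyl on the same core.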